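The compounds below may be only part of what the source reports. "The series", "measured", "known", "first", "only" and "open" are said of these compounds alone.

Compound 1 `O=Cc1ccc(-c2cn3ccnc3c(-c3ccc4ncn(C5CCCCC5)c4c3)n2)cc1` is the starting point. In a functional assay on CAKI-1 cells (Homo sapiens) for inhibition, read by sulforhodamine B assay, with a stated time of 48 h, tested at 10 uM (a lower number here means less inhibition, a higher number more inhibition at the concentration tested (going by the name of the read-out)), compound 1 gives 36.6%. Compound 2 `c1ccc2c(-c3cn4ccnc4c(-c4ccc5ncn(C6CCCCC6)c5c4)n3)cccc2c1` differs from compound 1 by naphthalen-1-yl in place of 4-formylphenyl on an aromatic carbon, and this step was a number 11.4 percentage points lower from compound 1 to compound 2 (beyond the scatter). Compound 3 `O=Cc1ccc(-c2cn3ccnc3c(-c3ccc4ncn(Cc5ccccc5)c4c3)n2)cc1` differs from compound 1 in its core by benzyl in place of cyclohexyl on an aromatic nitrogen; that step was no change at the digits printed from compound 1 to compound 3 (within the scatter), and compound 3 gives 36.6%, while compound 2 gives 25.2%. Compound 4 `c1ccc(Cn2cnc3ccc(-c4nc(-c5cccc6ccccc56)cn5ccnc45)cc32)cc1` has not yet been measured. It differs from compound 3 by naphthalen-1-yl in place of 4-formylphenyl on an aromatic carbon, the same change, at the same place in the shared core, that turned compound 1 into compound 2. Because that earlier change gave a number 11.4 percentage points lower from compound 1 to compound 2 (beyond the scatter), the estimated step is a number 11.6 percentage points lower from compound 3 to compound 4 (beyond the scatter). Compound 4 is therefore expected to give 25%, most likely between 12% and 38%.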

Compound 4, a percentage reported as inhibition, at one concentration (the size of the read-out at that concentration, not a potency): 27.1%
For compound 4 the middle estimate is 2.1 percentage points below the measured one, and the stated range covers the measured number.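

With naphthalen-1-yl in place of 4-formylphenyl, this assay gave a number 9.5 percentage points lower from compound 3 to compound 4 (within the scatter), and this agrees with the same change on the other core: the same change on two cores in this assay, a number 11.4 percentage points lower (beyond the scatter) from compound 1 to compound 2 and a number 9.5 percentage points lower (within the scatter) from compound 3 to compound 4, 1.9 percentage points apart, within the scatter of two such steps. Benzyl in place of cyclohexyl gave a number 1.9 percentage points higher from compound 2 to compound 4 (within the scatter), and this change also carries across: the same change on two cores in this assay, no change at the digits printed (within the scatter) from compound 1 to compound 3 and a number 1.9 percentage points higher (within the scatter) from compound 2 to compound 4, 1.9 percentage points apart, within the scatter of two such steps. Among these compounds, both changes therefore behave alike on the two cores, but this rests on only two pairs of compounds, and the second naphthalen-1-yl step alone does not stand clear of the scatter.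

Going by these compounds, whether this holds for other groups stays open, such as an amine or a carboxylic acid in place of the formyl group, or a longer chain in place of benzyl. All four numbers come from a single concentration, so they do not show potency.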